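The source may report more compounds than this note shows. Statements on the series, on what has been measured and on what is new or still open speak of the compounds shown alone.

Measured compounds in a functional assay on aorta (Rattus norvegicus, strain Wistar), in the presence of a further agent that is not named here; on this read-out higher numbers stand for larger maximal responses and lower numbers for smaller maximal responses:
- compound 1, `Cc1ccc2c(c1)N(C1=CCCC1=O)CC(C)(C)S2`, with 78%
- compound 2, `CC(=O)c1ccc2c(c1)N(C1=CCCC1=O)CC(C)(C)S2`, with 77%
- compound 3, `CC1CN(C2=CCCC2=O)c2cc(C(F)(F)F)ccc2S1`, with 63%

Among these three numbers compound 2 stands second highest. Its nearest neighbour is compound 1, whose value lies within the usual scatter of compound 2, so the two cannot be told apart. Compound 3 gives the lowest number of the three, and its distance from compound 2 lies beyond the scatter.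

The compound that has not yet been measured is compound 4, `CCc1ccc2c(c1)N(C1=CCCC1=O)CC(C)(C)S2`. It differs from compound 2 in one place only: ethyl in place of acetyl on an aromatic carbon.

Going by the values given here, one measured step bears on this change. Going a number 1 percentage points lower from compound 1 to compound 2 (within the scatter), acetyl in place of methyl on an aromatic carbon at the same position, left the maximal response essentially unchanged. Both a small alkyl group and the acetyl group at this site therefore gave much the same number. Ethyl in place of acetyl is another exchange of a small group at the same aromatic carbon, so no step beyond the scatter is expected in this assay.

Compound 4 is accordingly estimated at 77%, with a range from 67% to 87%. The expected step is no change at the digits printed from compound 2 to compound 4 (within the scatter), which is within the scatter.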

Compound 4, largest response reached (Emax), in percent of the reference or control that the assay uses: 69%
Compound 4: middle estimate off by 8 percentage points, on the high side, and the stated range covers the measured number.
By their numbers in this assay, from the lowest: compounds 3, 4, 2 and 1 (each within the scatter of the next, the first and the last beyond it).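

In this assay, putting ethyl in place of acetyl takes away the carbonyl oxygen, the one hydrogen-bond acceptor of that group, and the outcome is a number 8 percentage points lower from compound 2 to compound 4 (within the scatter) on this aromatic carbon. Seen from the other side, methyl in place of hydrogen on the saturated chain carbon bound to the aromatic carbon gives a number 9 percentage points lower from compound 1 to compound 4 (within the scatter) for the same compound, so one added chain carbon also stays inside the usual spread of repeated measurements. Methyl, acetyl and ethyl, one carrying a carbonyl and two carrying none, therefore cannot be told apart at this position on this read-out, which the single earlier step between methyl and acetyl could not show for a plain alkyl exchange or for the loss of the acceptor alone.

No measurement on these compounds offers a reason for this sameness. Still open, as far as these compounds go, is whether the maximal response would hold with a longer chain such as butyl, with a charged group such as an amine or a carboxylic acid, or with hydrogen alone at this aromatic carbon.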